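Trimming a methoxy group on a diaminoquinoxaline-type scaffold

The source may report more compounds than this note shows. Statements on the series, on what has been measured and on what is new or still open speak of the compounds shown alone.

The measured pair spans two structures: compound 1 `Nc1cc(N)c2nc(-c3ccccc3)c(Sc3ccc(F)cc3)nc2c1` and compound 2 `COc1cc(CNc2nc3cc(N)cc(N)c3nc2-c2ccccc2)cc(OC)c1OC`. In a functional assay on BT-549 cells (Homo sapiens) for inhibition, read by sulforhodamine B assay, with a stated time of 48 h (on this read-out higher numbers stand for weaker inhibition of growth and lower numbers for stronger inhibition of growth), compound 1 gives 43700 nM, while compound 2 gives 11200 nM, the lower of the two numbers, a gap beyond the usual scatter. Compound 3 `COc1ccc(CNc2nc3cc(N)cc(N)c3nc2-c2ccccc2)cc1OC` is the untested neighbour of compound 2, differing by hydrogen in place of methoxy on an aromatic carbon. Within the data shown here, with no measured step to lean on, the author expects this change to move the number little, if at all, beyond the scatter, at most a mild rise. Compound 3 is therefore estimated at 14000 nM, within 5000 nM to 40000 nM, a step of a 1.3-fold higher number from compound 2 to compound 3 (0.10 log units; within the scatter).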

Compound 3, concentration for total growth inhibition: 32400 nM
The estimate for compound 3 lay 2.3-fold (0.36 log units) below the measured number; measured number inside the range.
By their numbers in this assay, from the lowest: compound 2; then compounds 3 and 1 (each within the scatter of the next).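

In this assay, among these compounds, the first single-place step in this set is hydrogen in place of methoxy, giving a 2.9-fold higher number from compound 2 to compound 3 (0.46 log units; beyond the scatter), a modest loss of growth inhibition. It shows that this methoxy group, ortho to a methoxy group and meta to a large group, cannot be removed without a cost beyond the scatter. Nothing at hand shows why the number rises. The compounds shown leave open whether a hydroxyl, a fluorine or an amine on this aromatic carbon would keep the number of compound 2 or move toward that of compound 3. They also leave open what removing either remaining methoxy group would do.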